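This account rests on a few compounds, and the source may have more. Where it says the series, first, only, none or still open, it means among the compounds named here.

The measured compounds:

Compound 1, `CN(C(=O)CCc1ccccc1)c1ccc2[nH]c(-c3n[nH]c4ccccc34)cc2n1`, gives 18100 nM.
Compound 2, `CN(C(=O)c1ccc(Cl)cc1)c1ccc2[nH]c(-c3n[nH]c4ccccc34)cc2n1`, gives 2220 nM.
Compound 3, `CN(c1ccc2[nH]c(-c3n[nH]c4ccccc34)cc2n1)S(=O)(=O)c1ccc(Cl)cc1`, gives 18200 nM.

In a functional assay on A549 cells (Homo sapiens) for antiproliferative activity, read by MTT assay, with a stated time of 72 h (on this read-out lower numbers stand for stronger inhibition and higher numbers for weaker inhibition), compound 1 stands second highest of the three numbers. Its nearest neighbour is compound 3, with a 1.0-fold higher number from compound 1 to compound 3 (0.00 log units; within the scatter), and its furthest is compound 2, with an 8.2-fold lower number from compound 1 to compound 2 (0.91 log units; beyond the scatter).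

Compound 4, `CN(c1ccc2[nH]c(-c3n[nH]c4ccccc34)cc2n1)S(=O)(=O)c1ccc(Br)cc1`, has not yet been measured in this assay. It differs from compound 1 in one place: (4-bromophenyl)sulfonyl in place of phenethylcarbonyl on a nitrogen on an aromatic ring. Going by the values given here, two steps bear on this. The step of a 1.0-fold higher number from compound 1 to compound 3 (0.00 log units; within the scatter) already swaps the same phenethylcarbonyl for a (4-chlorophenyl)sulfonyl and changes nothing beyond the scatter. The step of an 8.2-fold higher number from compound 2 to compound 3 (0.91 log units; beyond the scatter) shows that, with the same 4-chlorophenyl held, moving from carbonyl to sulfonyl raises the number. Among the compounds with values here, compound 4 keeps the sulfonyl arrangement of compound 3 and trades chlorine for bromine, a change for which no step exists here. The expected step of a 1.1-fold lower number from compound 1 to compound 4 (0.03 log units; within the scatter) is therefore none beyond the scatter. Compound 4 is estimated at 17000 nM, with a range from 6000 nM to 45000 nM.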

Compound 4, half-maximal inhibitory concentration: 19700 nM
Estimate against measurement, compound 4: 1.2-fold (0.06 log units) below; low and high end bracket the measured number.
By their numbers in this assay, from the lowest: compound 2; then compounds 1, 3 and 4 (each within the scatter of the next).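

In this assay, going by these compounds alone, bromo in place of chloro on an aromatic carbon gives the first direct reading of this halogen swap (a 1.1-fold higher number from compound 3 to compound 4 (0.03 log units; within the scatter)), and the two sulfonyl compounds cannot be told apart. The bromo sulfonyl compound also stays level with the phenethylcarbonyl compound (a 1.1-fold higher number from compound 1 to compound 4 (0.04 log units; within the scatter)). It stands clearly apart from the 4-chlorophenyl amide (an 8.9-fold higher number from compound 2 to compound 4 (0.95 log units; beyond the scatter)), so the gap between that amide and the sulfonyl compounds holds with bromine as well, and nothing measured here explains these numbers.

Going by these compounds, whether the same bromo-for-chloro swap would also leave the number unchanged on the carbonyl side stays open. So does whether the halogen matters at all, since a plain phenylsulfonyl group, or a methoxy group or an amine in the halogen's place, could read differently.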